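From Nitrophenyl to Difluorophenyl: Expected Growth Inhibition

The source may hold more compounds than are shown below. What is called first, only, known or untested is meant among the compounds shown, and "the series" means these compounds.

Of the compounds shown here, two have so far been tested in a functional assay on Caco-2 cells (Homo sapiens) for inhibition, read by MTT assay, with a stated time of 48 h, tested at 10 uM; a higher number here means more inhibition of growth at the concentration tested, a lower number less inhibition of growth. Compound 1 `Cc1cc(=O)c2c(O)cc(OCc3ccc(Br)cc3)c([C@H]3CCN(C)C[C@H]3O)c2o1` gives 13%. Compound 2 `Cc1oc2c([C@H]3CCN(C)C[C@H]3O)c(O)cc(O)c2c(=O)c1C(O)c1ccc([N+](=O)[O-])cc1` gives 5%, the lower of the two numbers, although the gap to compound 1 lies within the scatter, so the two cannot be put in order. Compound 3 `Cc1oc2c([C@H]3CCN(C)C[C@H]3O)c(O)cc(O)c2c(=O)c1C(O)c1cc(F)cc(F)c1` has not yet been measured. It differs from compound 2 in one place: 3,5-difluorophenyl in place of 4-nitrophenyl on a saturated chain carbon bound to an aromatic carbon and an oxygen on a saturated carbon. Going by the values given here, no step between two measured compounds shows what such a change does here, so the expectation can rest only on the low numbers of compound 2 and compound 1. The expected step is a number 3 percentage points higher from compound 2 to compound 3 (within the scatter), which stays within the scatter and points in no particular direction. Compound 3 is therefore expected to give about 8%, with a range from 0% to 25%.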

Compound 3, percent growth inhibition at one concentration: 10%
Compound 3: middle estimate off by 2 percentage points, on the low side; the measured number falls inside the stated range.
By their numbers in this assay, from the lowest: compounds 2, 3 and 1 (each within the scatter of the next).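

In this assay, going by these compounds alone, placing 3,5-difluorophenyl instead of 4-nitrophenyl on the saturated chain carbon gives a number 5 percentage points higher from compound 2 to compound 3 (within the scatter) and provides the first direct reading of a change at this position. At this place, then, a phenyl ring carrying two fluorines and one carrying a nitro group cannot be told apart, and neither compound rises far on this scale. Nothing available explains this result.

The compounds shown leave open whether a different kind of group at this place, such as an amine or a carboxylic acid on the phenyl ring, or a longer chain in place of the ring, would produce a step beyond the scatter. As far as these compounds go, the part played by the hydroxy group on the same chain carbon also remains open.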